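The source may hold more compounds than are shown below. What is called first, only, known or untested is meant among the compounds shown, and "the series" means these compounds.

Measured in an ADME assay on L02 cells (Homo sapiens) for inhibition, read by CCK-8 assay, with a stated time of 48 h; a lower number here means a stronger inhibitor of growth, a higher number a weaker inhibitor of growth
compound 1 `CN1CCN(c2ccc(Nc3ncc(Cl)c(Nc4ccccc4)n3)nc2)CC1` gives 7990 nM
compound 2 `CN1CCN(c2ccc(Nc3ncc(Cl)c(NCc4ccccc4)n3)nc2)CC1` gives 20300 nM
compound 3 `Cc1ccc(Nc2nc(Nc3ccc(N4CCN(C)CC4)cn3)ncc2Cl)cc1` gives 13900 nM

Compound 3 stands in the middle of these three numbers, within the scatter of the other two (a 1.7-fold higher number from compound 1 to compound 3 (0.24 log units; within the scatter)) and (a 1.5-fold lower number from compound 2 to compound 3 (0.16 log units; within the scatter)). The next compound, compound 4 `CC(C)c1ccc(Nc2nc(Nc3ccc(N4CCN(C)CC4)cn3)ncc2Cl)cc1`, carries isopropyl in place of methyl on an aromatic carbon, para to a large group (isopropyl in place of methyl on an aromatic carbon). The closest measured change is methyl in place of hydrogen on that same aromatic carbon (a 1.7-fold higher number from compound 1 to compound 3 (0.24 log units; within the scatter)), and it stays within the scatter. Among the compounds with values here, the only step beyond the scatter is modest and is a different change, benzyl in place of phenyl on a nitrogen on an aromatic ring (a 2.5-fold higher number from compound 1 to compound 2 (0.40 log units; beyond the scatter)). Within the data shown here, no measured compound carries anything larger than methyl on that carbon, so the data give no direction and the range has to stay wide. No step beyond the scatter is therefore expected in this assay for this change. The expected step is small (a 1.1-fold lower number from compound 3 to compound 4 (0.03 log units; within the scatter)). For compound 4 the estimated value is 13000 nM (estimated range 6000 nM to 28000 nM)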

Compound 4, concentration for 50% growth inhibition: 13700 nM
Beside the measured number, compound 4's estimate is 1.1-fold (0.02 log units) below it; the range from low to high includes it.
By their numbers in this assay, from the lowest: compounds 1, 4, 3 and 2 (each within the scatter of the next, the first and the last beyond it).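

In this assay, within the data shown here, isopropyl in place of methyl on the aromatic carbon para to a large group gives no step beyond the scatter (a 1.0-fold lower number from compound 3 to compound 4 (0.01 log units; within the scatter)), so this carbon carries 3 heavy atoms where the earlier compounds carried no more than methyl, and the number does not separate from that of the methyl compound. Isopropyl in place of hydrogen on the same carbon also stays within the scatter (a 1.7-fold higher number from compound 1 to compound 4 (0.23 log units; within the scatter)), as does the change from benzyl on the nitrogen to 4-isopropylphenyl (a 1.5-fold lower number from compound 2 to compound 4 (0.17 log units; within the scatter)), so neither methyl nor isopropyl on this carbon yet reads as a change in this assay. No supporting measurement bears on why these numbers lie so close together.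

The compounds shown carry only hydrogen, methyl or isopropyl on this carbon, which leaves open whether an amine, a carboxylic acid or a longer chain there would give a step beyond the scatter. Also open, from the compounds shown here alone, is whether the same flat reading would hold with fluorine or a nitrile in place of the chlorine on the shared core.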